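Swapping a ring for a chain, with cytotoxicity in view

The source may report more compounds than this note shows. Statements on the series, on what has been measured and on what is new or still open speak of the compounds shown alone.

Of the compounds shown here, three have been tested for how much of them cultured human cells can tolerate. Compound 1 `COc1ccc(-c2cnc(NC(=O)C3CCCC3)n2C)cc1` carries a cyclopentyl group on its amide carbonyl. In a toxicity assay on THP-1 cells (Homo sapiens) for inhibition (a higher number here means that more compound is tolerated, a lower number that less compound is tolerated), compound 1 gives > 100000 nM, which is a limit of the test rather than a measured number. Compound 2 `COc1ccc(-c2cnc(NC(=O)c3cccc([N+](=O)[O-])c3)n2C)cc1` is likewise reported only as a limit, > 100000 nM, in this assay. Compound 3 `COc1ccc(-c2cn(C)c(NC(=O)c3ccc(F)cc3)n2)cc1` also reaches only a limit, > 50000 nM, in this assay. So compound 1 stands where most of the set stands: at the limit of > 100000 nM in this assay, at which 2 of the 3 values shown sit, while compound 3 sits at the limit of > 50000 nM in this assay, at which 1 of the 3 values shown sits. Going by the values given here, none of the three shows toxicity within the tested range, and no measured pair differs in a single place, so no step size can be read from these data.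

Compound 4 `CCCC(=O)Nc1ncc(-c2ccc(OC)cc2)n1C` is not yet measured. It differs from compound 1 by propyl in place of cyclopentyl on a carbonyl carbon. Since compound 1 sits at a limit, the step of a number no higher from compound 1 to compound 4 (the limit leaves the size open) is expected to be none beyond the scatter, with the result most likely again a limit. Compound 4 is therefore estimated at 100000 nM in this assay, within a range of 40000 nM to 300000 nM.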

Compound 4, half-maximal cytotoxic concentration: > 100000 nM
Compound 4: no number, only a limit (the forecaster's own chance of this, stated with the estimate: 85%); the middle value lies on the limit itself.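

Compound 1 and compound 4 both reach only a limit in this assay, so the step from cyclopentyl to propyl cannot be read: the limit of > 100000 nM in this assay, at which 3 of the 4 values shown sit.

The compounds shown leave open at what concentration any of them would begin to harm these cells, and whether the ring or the chain would make a difference there.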